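The compounds below may be only part of what the source reports. "The series", "measured", "known", "first", "only" and "open" are said of these compounds alone.

Measured so far:
Compound 1 `Cc1c(COc2ccnc(OCC3CCOCC3)c2)[nH]c2ccccc2c1=O`: 43 nM
Compound 2 `O=c1c(Cl)c(COc2cccc(OCC3CCOCC3)c2)[nH]c2ccccc12`: 12 nM

In a functional assay on HUVEC cells (Homo sapiens) for inhibition, using NADPH, with a stated time of 2 h (a lower number here means a stronger inhibitor, a higher number a weaker inhibitor), compound 2 has the lower of the two numbers, at 12 nM, while compound 1 stands at 43 nM. That makes compound 2 the stronger inhibitor by more than the usual scatter. Compound 3 `CC(C)c1c(COc2cccc(OCC3CCOCC3)c2)[nH]c2ccccc2c1=O` differs from compound 2 in one place, with isopropyl in place of chloro on an aromatic carbon.

Going by the values given here, no two measured compounds differ in just one place, so the data give no direct guide to this swap. With so little to go on, a modest rise in the number in this assay is expected, meaning a somewhat weaker inhibitor, though the uncertainty is wide. The expected change is a 2.5-fold higher number from compound 2 to compound 3 (0.40 log units; beyond the scatter). For compound 3 the estimated value is 30 nM, with an expected range of 8 nM to 120 nM.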

Compound 3, half-maximal inhibitory concentration: 54 nM
Beside the measured number, compound 3's estimate is 1.8-fold (0.26 log units) below it; measured number inside the range.
By their numbers in this assay, from the lowest: compound 2; then compounds 1 and 3 (each within the scatter of the next).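

In this assay, going by these compounds alone, putting isopropyl in place of chloro on this aromatic carbon, two atoms from the ring nitrogen, gives a 4.5-fold higher number from compound 2 to compound 3 (0.65 log units; beyond the scatter), the first change in a single place that can be read in this set. It shows that the group on this carbon matters to the number: here, the chloro compound is the stronger inhibitor, and the change is beyond the usual scatter. No measured information bears on what lies behind this step, so it stands as an observation without an explanation.

Still open, as far as these compounds go, is how a fluoro, a nitrile or a methoxy group on this same carbon would compare with chloro and isopropyl. Compound 1 carries a methyl group here but also differs from compound 2 in a second place, so the effect of methyl alone remains unsettled.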